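Chloro in place of trifluoromethyl: compound 2 to compound 3

A few compounds are considered here, and "the series" means these few. Any claim that something is new, unique, unknown or untested is made for them only; others in the source may bear on it.

Measured so far:
- compound 1 `Cn1nc(COc2cc(F)cc(F)c2)c2c1CCN(C(=S)Nc1ccc(Cl)cc1)C2`: > 10000 nM
- compound 2 `Cn1nc(COc2cc(F)cc(F)c2)c2c1CCN(S(=O)(=O)c1ccc(C(F)(F)F)cc1)C2`: > 10000 nM

Compound 1 and compound 2 share the same core and differ only in the group attached to the ring nitrogen. In an assay on cells for inhibition of Pendrin (Mus musculus), read by fluorescence, with a stated time of 10 min (on this read-out lower numbers stand for stronger inhibition and higher numbers for weaker inhibition), compound 1 gives > 10000 nM, which is a limit of the assay and not a number. In this assay compound 2 likewise gives > 10000 nM, again a limit. For the measured compounds named here, both values sit at the limit of > 10000 nM in this assay, at which 2 of the 2 values shown sit, so no step between measured compounds can be stated, and where compound 2 stands is known only as this limit.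

Compound 3 `Cn1nc(COc2cc(F)cc(F)c2)c2c1CCN(S(=O)(=O)c1ccc(Cl)cc1)C2` has not been measured. It differs from compound 2 by chloro in place of trifluoromethyl on an aromatic carbon; cut one bond further out, the same difference reads 4-(trifluoromethyl)phenyl to 4-chlorophenyl. Going by the values given here, with both measured compounds sitting at the limit, no step in this assay from compound 2 to compound 3 beyond the scatter is expected, in either direction. Compound 3 is expected to give 20000 nM, with a range from 5000 nM to 80000 nM, most likely reported again as a limit. The expected step is a step that the limit leaves unreadable from compound 2 to compound 3, estimated as none beyond the scatter.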

Compound 3, half-maximal inhibitory concentration: > 10000 nM
Compound 3: a limit, no number; the forecaster's own chance of this, stated with the estimate: 85%; the middle value is on the limit's open side.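

Compound 3 gives > 10000 nM in this assay, a limit of the assay and not a number. For the compounds shown here, no step from compound 2 to compound 3 or from compound 1 to compound 3 can be read: the limit of > 10000 nM in this assay, at which 3 of the 3 values shown sit. The compounds shown leave open whether any group on the ring nitrogen of the shared core gives a readable value, and what chloro in place of trifluoromethyl does to the value.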